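Swapping a fluorobenzoyl amide for a pyrimidine amine

A few compounds are considered here, and "the series" means these few. Any claim that something is new, unique, unknown or untested is made for them only; others in the source may bear on it.

Compound 1 `C[C@@H](Cn1ccc(-c2ccc(C#N)c(Cl)c2)n1)NC(=O)c1ccccc1F`: in an ADME assay on PC-3 cells (Homo sapiens) for cytotoxicity, read by CCK-8 assay, with a stated time of 6 days (on this read-out lower numbers stand for stronger inhibition and higher numbers for weaker inhibition), compound 1 gives > 30000 nM, which is a limit of the assay rather than a number.
Compound 2 `CC(Cn1ccc(-c2ccc(C#N)c(Cl)c2)n1)C(=O)Nc1cc[nH]n1`: compound 2 gives > 30000 nM, again only a limit.
Compound 3 `CC(=O)c1cccc(NC(=O)C(C)Cn2ccc(-c3ccc(C#N)c(Cl)c3)n2)c1`: compound 3 gives > 30000 nM, again only a limit.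

Compound 1 therefore stands nowhere in particular on these numbers: it sits at the limit, and so do the two other values shown, because of the limit of > 30000 nM in this assay, at which 3 of the 3 values shown sit. Going by the values given here, the one measured step between single-change neighbours, from compound 2 to compound 3 a step that the two limits leave unreadable from compound 2 to compound 3, cannot be read either, since both ends are limits.

Compound 4 `C[C@@H](Cn1ccc(-c2ccc(C#N)c(Cl)c2)n1)Nc1cncnc1` is the next member of the series. Compared with compound 1 the change is pyrimidin-5-yl in place of (2-fluorophenyl)carbonyl on an amine nitrogen. Among the compounds with values here, no measured step bears on this change, and the three values on hand give no readable size in any direction. Within the data shown here, what they do show is that every compound so far has stayed at the limit, with nothing beyond the scatter to build on.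

On that basis compound 4 is expected to give 40000 nM, with a range from 15000 nM to 100000 nM, most likely reported again as a limit. The step from compound 1 to compound 4 is thus estimated as a step that the limit leaves unreadable from compound 1 to compound 4, meaning no readable change is expected.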

Compound 4, half-maximal inhibitory concentration: > 30000 nM
Compound 4 gave a limit, no number; the forecaster's own chance of this, stated with the estimate: 80%; the middle value is on the limit's open side.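

No size can be read for the step from compound 1 to compound 4, because both compounds give only a limit: the limit of > 30000 nM in this assay, at which 4 of the 4 values shown sit.

The compounds shown leave open whether pyrimidin-5-yl in place of (2-fluorophenyl)carbonyl on an amine nitrogen changes the result in this assay at all, and what actual value any of these compounds would have.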